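Swapping the amide-borne ring system: expected effect on stability

A few compounds are considered here, and "the series" means these few. Any claim that something is new, unique, unknown or untested is made for them only; others in the source may bear on it.

Compound 1 `O=C(NCc1ccc(S(=O)(=O)c2cccc(C(F)(F)F)c2)cc1)c1cc2cnccc2[nH]1` and compound 2 `O=C(NCc1ccc(S(=O)(=O)c2cccc(C(F)(F)F)c2)cc1)c1cnc2nccn2c1` share everything except the ring system on the carbonyl carbon; that change is a group of 9 heavy atoms (6 carbon, 3 nitrogen; one five-membered aromatic ring with 2 hetero atoms, one six-membered aromatic ring with 2 hetero atoms) in place of a group of 9 heavy atoms (7 carbon, 2 nitrogen; one five-membered aromatic ring with 1 hetero atom, one six-membered aromatic ring with 1 hetero atom), on a carbonyl carbon. In an ADME assay on microsomes from liver (Mus musculus) for metabolic stability, read by LC-MS, with a stated time of 30 min, tested at 1 uM (a lower number here means that less of the compound is left, a higher number that more of the compound is left), compound 1 gives 49% and compound 2 gives 27%, so the swap made a number 22 percentage points lower from compound 1 to compound 2 (beyond the scatter). Compound 3 `O=C(NCc1ccc(S(=O)(=O)c2ccccc2)cc1)c1cc2cnccc2[nH]1` differs from compound 1 by hydrogen in place of trifluoromethyl on an aromatic carbon, and in this assay compound 3 gives 54%, a change of a number 5 percentage points higher from compound 1 to compound 3 (within the scatter). Compound 4 `O=C(NCc1ccc(S(=O)(=O)c2ccccc2)cc1)c1cnc2nccn2c1` is not yet measured; it stands to compound 3 as compound 2 stands to compound 1, the change being (a group of 9 heavy atoms (6 carbon, 3 nitrogen; one five-membered aromatic ring with 2 hetero atoms, one six-membered aromatic ring with 2 hetero atoms) in place of a group of 9 heavy atoms (7 carbon, 2 nitrogen; one five-membered aromatic ring with 1 hetero atom, one six-membered aromatic ring with 1 hetero atom), on a carbonyl carbon), made at the same place. Because the earlier swap gave a number 22 percentage points lower from compound 1 to compound 2 (beyond the scatter), the step from compound 3 to compound 4 in this assay is expected to be about a number 22 percentage points lower from compound 3 to compound 4 (beyond the scatter). Compound 4 is therefore estimated at 32%, plausibly between 18% and 46%.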

Compound 4, percent of the compound remaining: 30%
Compound 4: the middle estimate sits 2 percentage points above what was measured; low and high end bracket the measured number.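

In this assay, the ring swap on the carbonyl carbon gives a number 24 percentage points lower from compound 3 to compound 4 (beyond the scatter), which closely repeats the step on the core of compound 1: the same change on two cores in this assay, a number 22 percentage points lower (beyond the scatter) from compound 1 to compound 2 and a number 24 percentage points lower (beyond the scatter) from compound 3 to compound 4, 2 percentage points apart, within the scatter of two such steps. Hydrogen in place of trifluoromethyl gives a number 3 percentage points higher from compound 2 to compound 4 (within the scatter), a step that stays within the scatter with either ring system on the carbonyl carbon: the same change on two cores in this assay, a number 5 percentage points higher (within the scatter) from compound 1 to compound 3 and a number 3 percentage points higher (within the scatter) from compound 2 to compound 4, 2 percentage points apart, within the scatter of two such steps. This shows that the ring swap carried over between these two cores, but it does not show why the number falls or that the same step would appear on any other core.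

The compounds shown leave open how a group carrying an amine or a carboxylic acid on the carbonyl carbon would read in this assay. They also leave open whether a nitrile in place of trifluoromethyl would match hydrogen.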